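Trifluoromethoxy for methoxy on the aryloxy ring

The compounds below may be only part of what the source reports. "The series", "measured", "known", "first", "only" and "open" are said of these compounds alone.

Compound 1 `Cc1nn(C)c(Oc2ccc(F)cc2)c1/C=N\OCc1c(Cl)c(-c2ccc(F)cc2)nn1C`: 8020 nM
Compound 2 `COc1ccc(Oc2c(/C=N\OCc3c(Cl)c(-c4ccc(F)cc4)nn3C)c(C)nn2C)cc1`: 1180 nM

In a functional assay on HCT-116 cells (Homo sapiens) for antiproliferative activity, read by MTT assay, with a stated time of 72 h (on this read-out lower numbers stand for stronger inhibition and higher numbers for weaker inhibition), compound 2 gives 1180 nM, the lowest of the two numbers shown; its nearest neighbour is compound 1, which in this assay gives 8020 nM. Among the measured compounds shown here, the one step available, a 6.8-fold lower number from compound 1 to compound 2 (0.83 log units; beyond the scatter), concerns the same aromatic position as the change now considered. Compound 3 `Cc1nn(C)c(Oc2ccc(OC(F)(F)F)cc2)c1/C=N\OCc1c(Cl)c(-c2ccc(F)cc2)nn1C` differs from compound 2 by trifluoromethyl in place of methyl on an oxygen on an aromatic ring. For the measured compounds named here, no measured step shows a trifluoromethyl entering in place of a methyl, so the earlier step indicates only that this position tolerates substitution and that changes here can shift this assay beyond the scatter. A step of modest size in either direction is plausible. Compound 3 is expected to give about 2000 nM in this assay, within a range of 500 nM to 8000 nM, which corresponds to an estimated step of a 1.7-fold higher number from compound 2 to compound 3 (0.23 log units; within the scatter).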

Compound 3, half-maximal inhibitory concentration: 2310 nM
Beside the measured number, compound 3's estimate is 1.2-fold (0.06 log units) below it; the measured number falls inside the stated range.
By their numbers in this assay, from the lowest: compounds 2 and 3 (each within the scatter of the next); then compound 1.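

In this assay, trifluoromethyl in place of methyl on the oxygen gives a 2.0-fold higher number from compound 2 to compound 3 (0.29 log units; within the scatter) and so does not separate the two compounds on this read-out. Trifluoromethoxy in place of fluoro on the aromatic carbon gives a 3.5-fold lower number from compound 1 to compound 3 (0.54 log units; beyond the scatter) and so makes compound 3 a second compound, after compound 2, that stands apart from compound 1 beyond the scatter. Nothing available here accounts for these numbers.

The compounds shown leave open whether an amine, a carboxylic acid or a longer alkoxy chain on this aromatic carbon would stay within the scatter of compound 2 and compound 3 or move away from them. They also leave open whether the same exchange of methoxy for trifluoromethoxy would read the same way on a different core.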